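A few compounds are considered here, and "the series" means these few. Any claim that something is new, unique, unknown or untested is made for them only; others in the source may bear on it.

Measured so far:
- compound 1, `NS(=O)(=O)c1ccc(N2C(=O)CC(C3CCCCC3=O)C2=O)cc1`: 21300 nM
- compound 2, `O=C1CCOCC1C1CC(=O)N(c2ccccc2)C1=O`: 56600 nM
- compound 3, `CC(=O)CC1CC(=O)N(c2ccccc2)C1=O`: 63900 nM

All three were run in an assay on Sf21 cells for inhibition of cytochrome c oxidase subunit 2 (Homo sapiens), read by spectrophotometry, with a stated time of 5 min; on this read-out higher numbers stand for weaker inhibition and lower numbers for stronger inhibition. Compound 3 has the highest of the three numbers. Compound 2 lies within the scatter of compound 3, so the two cannot be told apart. Compound 1 stands beyond the scatter, with a lower number than compound 3; compound 1 differs from compound 3 in more than one place, so no single cause can be read off.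

Compound 4, `O=C1CCCC1C1CC(=O)N(c2ccccc2)C1=O`, has not been measured. It differs from compound 3 in one place: 2-oxocyclopentyl in place of 2-oxopropyl on a saturated ring carbon. For the measured compounds named here, no single-change step between measured compounds is available to calibrate this change. Compound 2 and compound 3, both carrying a ketone on that same ring carbon, one in a ring and one in a chain, sit within the scatter of each other, which suggests the ring closure itself moves little. The expected step in this assay from compound 3 to compound 4 is therefore small, most likely not beyond the scatter, with any lean toward a lower number: a 1.3-fold lower number from compound 3 to compound 4 (0.11 log units; within the scatter). Compound 4 is estimated at 50000 nM, with a range from 20000 nM to 120000 nM.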

Compound 4, half-maximal inhibitory concentration: 51400 nM
Beside the measured number, compound 4's estimate is 1.0-fold (0.01 log units) below it, and the stated range covers the measured number.
By their numbers in this assay, from the lowest: compound 1; then compounds 4, 2 and 3 (each within the scatter of the next).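

In this assay, 2-oxocyclopentyl in place of 2-oxopropyl on the saturated ring carbon gives a 1.2-fold lower number from compound 3 to compound 4 (0.09 log units; within the scatter). For the compounds shown here, this is the first single-change step read at this position, and it shows that a group of 6 heavy atoms with a five-membered carbon ring and a group of 4 heavy atoms with no ring cannot be told apart here when each carries one ketone. No measured evidence bears on this result.

Every group shown at this position carries a ketone, so the effect of a plain cyclopentyl, an amine or a carboxylic acid there remains open. The contribution of the sulfonamide in compound 1 also remains open, as no pair shown differs in that place alone.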